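Sulfonylation of the Phenol: From Compound 3 to Compound 4

The source may hold more compounds than are shown below. What is called first, only, known or untested is meant among the compounds shown, and "the series" means these compounds.

Compound 1 `C=C1C(=O)[C@]23C[C@@]1(O)CC[C@H]2c1ccc(OS(=O)(=O)c2ccc(C)cc2)c(C)c1[C@@H]3Cn1cc(-c2ccc(Br)cc2)nn1`: 1630 nM
Compound 2 `C=C1C(=O)[C@]23C[C@@]1(O)CC[C@H]2c1ccc(OS(=O)(=O)c2ccc(C)cc2)c(C)c1[C@@H]3Cn1cc(-c2ccc(Cl)cc2)nn1`: 1870 nM
Compound 3 `C=C1C(=O)[C@]23C[C@@]1(O)CC[C@H]2c1ccc(O)c(C)c1[C@@H]3Cn1cc(-c2ccc(C)cc2)nn1`: 1260 nM

Of the compounds shown here, three have been measured in a functional assay on A549 cells (Homo sapiens) for cytotoxicity, read by MTT assay, with a stated time of 4 days; a lower number here means a stronger inhibitor, a higher number a weaker inhibitor. Compound 3 gives 1260 nM, the lowest of the three numbers, but its gaps to compound 1 and to compound 2 both lie within the scatter, so the three cannot be separated. Within the data shown here, the only single-point step among them is a 1.1-fold higher number from compound 1 to compound 2 (0.06 log units; within the scatter), which concerns the halogen on the phenyl of the triazole and leaves the phenol untouched.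

Compound 4 `C=C1C(=O)[C@]23C[C@@]1(O)CC[C@H]2c1ccc(OS(=O)(=O)c2ccc(C)cc2)c(C)c1[C@@H]3Cn1cc(-c2ccc(C)cc2)nn1` differs from compound 3 by (4-methylphenyl)sulfonyl in place of hydrogen on an oxygen on an aromatic ring. Among the measured compounds shown here, no measured pair isolates this change. For the measured compounds named here, the data show only that compound 1 and compound 2, which carry the same sulfonyl ester, sit within the scatter of compound 3, which carries the free phenol; their triazole aryl groups differ as well, so this is an indirect hint at best. The expected step is a 1.2-fold higher number from compound 3 to compound 4 (0.08 log units; within the scatter), within the scatter. Compound 4 is estimated at 1500 nM, with a range from 700 nM to 3200 nM.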

Compound 4, half-maximal inhibitory concentration: 1830 nM
For compound 4 the middle estimate is 1.2-fold (0.09 log units) below the measured one; low and high end bracket the measured number.
By their numbers in this assay, from the lowest: compounds 3, 1, 4 and 2 (each within the scatter of the next).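

In this assay, among these compounds, the pair isolates the sulfonyl ester for the first time: a 1.5-fold higher number from compound 3 to compound 4 (0.16 log units; within the scatter), so (4-methylphenyl)sulfonyl in place of hydrogen on an oxygen on an aromatic ring gives no difference that can be separated from the scatter. With that ester held constant, methyl in place of a halogen on an aromatic carbon is also not separable, in either a 1.0-fold lower number from compound 2 to compound 4 (0.01 log units; within the scatter) or a 1.1-fold higher number from compound 1 to compound 4 (0.05 log units; within the scatter). No supporting measurement bears on these results.

The compounds shown leave open whether a different group on that oxygen, such as methanesulfonyl or acetyl, would separate from the free hydroxy. They also leave open whether an amine or a carboxylic acid in place of the methyl on an aromatic carbon would give a number beyond the scatter.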